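The source may hold more compounds than are shown below. What is called first, only, known or untested is meant among the compounds shown, and "the series" means these compounds.

Measured compounds and their values:

compound 1 `Cc1ccc(-c2nc(SCc3cn(CC(=O)NC(=O)Nc4ccccn4)nn3)nc(Nc3ccc(C(C)C)cc3)c2C#N)cc1` — 19300 nM
compound 2 `COc1ccccc1Nc1nc(SCc2cn(CC(=O)NC(=O)Nc3ccccn3)nn2)nc(-c2ccc(C)cc2)c1C#N` — 7960 nM
compound 3 `Cc1ccc(Nc2nc(SCc3cn(CC(=O)NC(=O)Nc4ccccn4)nn3)nc(-c3ccc(C)cc3)c2C#N)cc1` — 9890 nM

All three were read in a functional assay on MGC-803 cells (Homo sapiens) for inhibition, read by MTT assay, with a stated time of 72 h; a lower number here means a stronger inhibitor, a higher number a weaker inhibitor. Compound 3 stands second highest of the three numbers; its nearest neighbour is compound 2, and the pair differ by a 1.2-fold higher number from compound 2 to compound 3 (0.09 log units; within the scatter), which is within the scatter. Its furthest neighbour is compound 1, and that gap, a 2.0-fold lower number from compound 1 to compound 3 (0.29 log units; within the scatter), is also within the scatter. Among the compounds with values here, the only step beyond the scatter is a 2.4-fold lower number from compound 1 to compound 2 (0.38 log units; beyond the scatter), and it is modest.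

Compound 4 `Cc1ccc(-c2nc(SCc3cn(CC(=O)NC(=O)Nc4ccccn4)nn3)nc(Nc3cccc(Cl)c3)c2C#N)cc1` is not yet measured. It differs from compound 3 by 3-chlorophenyl in place of 4-methylphenyl on a nitrogen on an aromatic ring. Within the data shown here, the steps that bear on it are the two earlier swaps of the aryl group on that same nitrogen: a 2.4-fold lower number from compound 1 to compound 2 (0.38 log units; beyond the scatter) and a 1.2-fold higher number from compound 2 to compound 3 (0.09 log units; within the scatter). Both are small, so a further aryl swap there is expected to move the number little, if at all beyond the scatter, in this assay.

Compound 4 is therefore estimated at 8500 nM, in the range 3500 nM to 21000 nM, which means an expected step of a 1.2-fold lower number from compound 3 to compound 4 (0.07 log units; within the scatter).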

Compound 4, half-maximal inhibitory concentration: 7890 nM
The estimate for compound 4 lay 1.1-fold (0.03 log units) above the measured number; measured number inside the range.
By their numbers in this assay, from the lowest: compounds 4, 2, 3 and 1 (each within the scatter of the next, the first and the last beyond it).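

In this assay, 3-chlorophenyl on this nitrogen cannot be told apart from 4-methylphenyl (a 1.3-fold lower number from compound 3 to compound 4 (0.10 log units; within the scatter)) or from 2-methoxyphenyl (a 1.0-fold lower number from compound 2 to compound 4 (0.00 log units; within the scatter)), so a chlorine-bearing ring now joins the methyl- and methoxy-bearing rings with no separation among them. Against 4-isopropylphenyl the change gives a modest step beyond the scatter (a 2.4-fold lower number from compound 1 to compound 4 (0.39 log units; beyond the scatter)), the second such step after (a 2.4-fold lower number from compound 1 to compound 2 (0.38 log units; beyond the scatter)), although (a 2.0-fold lower number from compound 1 to compound 3 (0.29 log units; within the scatter)) stays within the scatter and goes against any clean separation of the 4-isopropylphenyl compound from the rest. No measurement given here bears on why these aryl groups read alike.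

As far as these compounds go, it remains open whether an aryl ring carrying a carboxylic acid or an amine on this nitrogen, or a saturated ring in its place, would move the number beyond the scatter. Also open, from the compounds shown here alone, is how much the number depends on the remainder of the molecule, which all four compounds share.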